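A few compounds are considered here, and "the series" means these few. Any claim that something is new, unique, unknown or untested is made for them only; others in the source may bear on it.

In a functional assay on MCF7 cells (Homo sapiens) for antiproliferative activity (on this read-out higher numbers stand for weaker inhibition and lower numbers for stronger inhibition), compound 1 `CC(=O)Oc1ccc(C(=O)Nc2cc3ccc(OCC4CCN(C)C4)c(C)c3oc2=O)cc1CC=C(C)C` gives 1880 nM. Compound 2 `CC(C)=CCc1cc(C(=O)Nc2cc3ccc(OCCCN4CCCCC4)c(C)c3oc2=O)ccc1O` is reported at > 50000 nM in this assay, and this is a limit of the assay, not a measured number. Compound 2 therefore stands on (the limit of > 50000 nM in this assay, at which 1 of the 2 values shown sits).

Compound 3 `CCCNCCCOc1ccc2cc(NC(=O)c3ccc(O)c(CC=C(C)C)c3)c(=O)oc2c1C` has not yet been measured. It differs from compound 2 by a single change, propylamino in place of piperidin-1-yl on a saturated chain carbon, three bonds along the chain from an oxygen on an aromatic ring. Among the compounds with values here, no measured step between two compounds shows what such an exchange does, so any forecast is loose. Compound 1, at 1880 nM, shows that a number can be obtained on the shared core, although it differs from compound 2 in more than one place. A moderate move towards stronger inhibition is therefore expected, but compound 3 may also stay at the limit. The expected change is an at least 2.7-fold lower number from compound 2 to compound 3 (0.44 log units; beyond the scatter), an estimate that counts from a limit and not from a number. Compound 3 is estimated at 18000 nM, with an expected range of 3000 nM to 50000 nM.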

Compound 3, half-maximal inhibitory concentration: 980 nM
Beside the measured number, compound 3's estimate is 18-fold (1.26 log units) above it; the measured number lies below the stated range.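

In this assay, propylamino in place of piperidin-1-yl on a saturated chain carbon, three bonds along the chain from an oxygen on an aromatic ring, gives an at least 51-fold lower number from compound 2 to compound 3 (1.70 log units; beyond the scatter), so a single exchange at this position is enough to bring a number within reach of the read-out. On these data alone, compound 2 stands at a limit of the assay and not at a number, so the true size of this step stays unknown and the printed size is only its lower bound: the limit of > 50000 nM in this assay, at which 1 of the 3 values shown sits. Compound 1 differs from compound 2 in more than one place and could tie no effect to one site, whereas this step ties a large change to this one exchange, of a six-membered non-aromatic ring with no hydrogen-bond donor for an open chain with one.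

The compounds shown leave open whether the loss of the ring or the gain of the hydrogen-bond donor carries the step, and a dimethylamino group at this place, open like propylamino yet without a hydrogen on its nitrogen, would separate the two. They also leave open how the length of the chain on that nitrogen matters, as an ethylamino or a butylamino group would show.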